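The source may report more compounds than this note shows. Statements on the series, on what has been measured and on what is new or still open speak of the compounds shown alone.

Three compounds share a common core. Compound 1 `COc1cc(C)cc(-c2c(-c3ccnc(-c4ccc(N(C)C)cc4)c3)cnn2CC#N)c1` gives 26% in a functional assay on HOP-92 cells (Homo sapiens) for cytotoxicity, read by sulforhodamine B assay, with a stated time of 48 h, tested at 0.001 uM; on this read-out higher numbers stand for a weaker effect at the one concentration tested and lower numbers for a stronger effect. Compound 2 `COc1cc(C)cc(-c2nn(CC#N)cc2-c2ccnc(-c3ccc(N(C)C)cc3)c2)c1` gives 102%, the highest number of the three and so the weakest effect; compound 3 `COc1cc(C)cc(-c2nn(CC#N)cc2-c2ccc(-c3cccc(C(C)=O)c3)nc2)c1` gives 84%. The gap from compound 2 to compound 3 and the larger gap to compound 1 both lie beyond the usual scatter.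

Compound 4 `Cc1cc(O)cc(-c2nn(CC#N)cc2-c2ccnc(-c3ccc(N(C)C)cc3)c2)c1` has not been measured. It differs from compound 2 in one place: hydrogen in place of methyl on an oxygen on an aromatic ring, so a methoxy becomes a hydroxy. A change this small is expected to move the number little, and the step of a number 6 percentage points lower from compound 2 to compound 4 (within the scatter) is expected to stay within the scatter. Compound 4 is therefore estimated at 96%, within a range from 76% to 112%.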

Compound 4, a percentage reported as activity, at one concentration (the size of the read-out at that concentration, not a potency): 80%
Beside the measured number, compound 4's estimate is 16 percentage points above it; the measured number falls inside the stated range.
By their numbers in this assay, from the lowest: compound 1; then compounds 4 and 3 (each within the scatter of the next); then compound 2.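

Replacing methoxy with hydroxy on the 3-methoxy-5-methylphenyl group gives a number 22 percentage points lower from compound 2 to compound 4 (beyond the scatter) in this assay. Within the data shown here, this is the first one-place comparison in the set, and it shows that this oxygen is sensitive: losing a single methyl carbon shifts the read-out towards a stronger effect, though only modestly. Nothing available explains the shift.

Still open, on these data alone, is how a longer chain on this oxygen, such as ethoxy, or an amine in place of the oxygen would read. Also open, as far as these compounds go, is whether the same swap would act alike in compound 1 or compound 3.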